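The compounds below may be only part of what the source reports. "The series", "measured", "known", "first", "only" and "open" are said of these compounds alone.

Measured:
compound 1 `O=C(NCCCNc1nc(Nc2cccc(F)c2)ncc1C1CC1)c1cccs1` — 110 nM in an assay on isolated protein for inhibition of serine/threonine-protein kinase TBK1 (Homo sapiens); on this read-out lower numbers stand for stronger inhibition and higher numbers for weaker inhibition
compound 2 `O=C(NCCCNc1nc(NC2CCCCC2)ncc1C1CC1)c1cccs1` — for compound 2 this assay returns only a limit, > 10000 nM

Compound 2 thus has no number, only (the limit of > 10000 nM in this assay, at which 1 of the 2 values shown sits). Compound 3 `O=C(NCCCNc1nc(Nc2ccccc2F)ncc1C1CC1)c1cccs1` differs from compound 2 by 2-fluorophenyl in place of cyclohexyl on a nitrogen on an aromatic ring. Going by the values given here, the single measured step that bears on this is the reverse exchange, an at least 90-fold higher number from compound 1 to compound 2 (1.95 log units; beyond the scatter), where the aromatic ring was lost. Restoring an aromatic ring is expected to recover most of that loss; the fluorine position of compound 3 differs from compound 1 and is untested. Compound 3 is expected near 300 nM, between 80 nM and 3000 nM, meaning an expected step of an at least 33-fold lower number from compound 2 to compound 3 (1.52 log units; beyond the scatter).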

Compound 3, half-maximal inhibitory concentration: 820 nM
Compound 3: the middle estimate sits 2.7-fold (0.44 log units) below what was measured; measured number inside the range.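

On the nitrogen on an aromatic ring, 2-fluorophenyl in place of cyclohexyl gives an at least 12-fold lower number from compound 2 to compound 3 (1.08 log units; beyond the scatter), so the gain does not depend on 3-fluorophenyl alone. Compound 2 has only a limit, > 10000 nM. Where the fluorine sits on the phenyl also matters: 2-fluorophenyl in place of 3-fluorophenyl gives a 7.5-fold higher number from compound 1 to compound 3 (0.87 log units; beyond the scatter).

Left open is whether an unsubstituted phenyl or a pyridyl group on this nitrogen would match compound 1. Also open, going by these compounds, is whether the fluorine contributes anything at all.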